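Cinnamate esters on a shared trimethoxyphenyl-propenyl core: step to compound 3

The compounds below may be only part of what the source reports. "The series", "measured", "known", "first", "only" and "open" are said of these compounds alone.

Measured so far:
compound 1 `COc1cc(OC)c(OC)cc1/C=C/COC(=O)/C=C/c1ccc(OC)c(OC)c1` gives 75%
compound 2 `COc1cc(OC)c(OC)cc1/C=C/COC(=O)/C=C/c1ccc(F)cc1` gives 75%

In a functional assay on the whole organism (strain Kunming) with Mus musculus as the target, with a stated time of 0.5 h, at a dose of 300 mg/kg by the intraperitoneal route (on this read-out lower numbers stand for a stronger effect and higher numbers for a weaker effect at the one dose given), compound 1 gives 75%. Compound 2 `COc1cc(OC)c(OC)cc1/C=C/COC(=O)/C=C/c1ccc(F)cc1` differs from compound 1 by 4-fluorophenyl in place of 3,4-dimethoxyphenyl on a double-bonded chain carbon bound to a double-bonded chain carbon, and in this assay compound 2 gives 75%; the step of no change at the digits printed from compound 1 to compound 2 (within the scatter) lies within the scatter, so compound 2 stands level with compound 1 on the numbers shown.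

Compound 3 `COc1cc(OC)c(OC)cc1/C=C/COC(=O)/C=C/c1cccc(Br)c1` is not yet measured. It differs from compound 2 by 3-bromophenyl in place of 4-fluorophenyl on a double-bonded chain carbon bound to a double-bonded chain carbon.

For the measured compounds named here, the only step so far that exchanges the aryl group on the double-bonded chain carbon is no change at the digits printed from compound 1 to compound 2 (within the scatter), and it produced no change beyond the scatter. Going by the values given here, the change from compound 2 to compound 3 again exchanges only that aryl group, so no step beyond the scatter is expected in this assay, in either direction: the expected step is no change at the digits printed from compound 2 to compound 3 (within the scatter).

Compound 3 is therefore estimated at 75% in this assay, within a range from 60% to 90%.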

Compound 3, a percentage reported as activity, at one dose (the size of the read-out at that dose, not a potency): 50%
Estimate against measurement, compound 3: 25 percentage points above; measured number below the stated range.
By their numbers in this assay, from the lowest: compound 3; then compounds 1 and 2 (each within the scatter of the next).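

In this assay the aryl group on a double-bonded chain carbon bound to a double-bonded chain carbon now proves able to move the read-out: 3-bromophenyl in place of 4-fluorophenyl gives a number 25 percentage points lower from compound 2 to compound 3 (beyond the scatter), and 3-bromophenyl in place of 3,4-dimethoxyphenyl gives a number 25 percentage points lower from compound 1 to compound 3 (beyond the scatter). The earlier exchange at this place gave no change at the digits printed from compound 1 to compound 2 (within the scatter), so a change of aryl group here does not always leave the number in place, and among the three compounds only 3-bromophenyl stands apart, with the stronger effect at the one dose given. The data offer no measurement that accounts for this shift.

The step from compound 2 to compound 3 exchanges both the halogen and the place it occupies on the ring, so the compounds shown do not separate the contribution of bromine from that of its position, a question that 4-bromophenyl and 3-fluorophenyl would address. As far as these compounds go, whether the effect extends to other groups at this place, such as 3-chlorophenyl or 3-nitrophenyl, and whether it holds at other doses, remains open.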